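A few compounds are considered here, and "the series" means these few. Any claim that something is new, unique, unknown or untested is made for them only; others in the source may bear on it.

Measured so far in an assay on membranes from lung (Cavia porcellus) for inhibition of leukotriene B4 receptor (Homo sapiens); on this read-out lower numbers stand for stronger inhibition and higher numbers for weaker inhibition:
- compound 1 `CCCc1c(OCCCOc2cc(O)c(C(C)=O)cc2CC)cccc1OCc1ccccc1C(=O)O`: 244 nM
- compound 2 `CCCc1cc(Oc2ccc(C(=O)O)cc2)ccc1OCCCOc1cc(O)c(C(C)=O)cc1CC`: 1200 nM

Compound 1 holds the lowest of the two numbers in this assay; compound 2 sits higher, and the gap between the two lies beyond the scatter. For the measured compounds named here, the two compounds differ in more than one place, so no single step between them can be read.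

Compound 3 `CCCc1c(OCCCOc2cc(O)c(C(C)=O)cc2CC)cccc1Oc1ccccc1C(=O)O` is the next member and is still to be measured in this assay. It departs from compound 1 in one place: 2-carboxyphenyl in place of 2-carboxybenzyl on an oxygen on an aromatic ring. Going by the values given here, no measured pair shows this exact change, and compound 2 cannot serve as a reference for it, since it differs from compound 1 elsewhere as well.

Within the shared core the change is small, so the step is expected to stay modest; the direction is open, with a slight lean toward a lower number. For compound 3 the expected step is a 1.6-fold lower number from compound 1 to compound 3 (0.21 log units; within the scatter). Compound 3 is therefore estimated at 150 nM in this assay, with a range from 40 nM to 800 nM.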

Compound 3, inhibition constant: 39 nM
The estimate for compound 3 lay 3.8-fold (0.59 log units) above the measured number; measured number outside the range, below it.
By their numbers in this assay, from the lowest: compound 3; then compound 1; then compound 2.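

In this assay, for the compounds shown here, replacing 2-carboxybenzyl with 2-carboxyphenyl on an oxygen on an aromatic ring gives a 6.3-fold lower number from compound 1 to compound 3 (0.80 log units; beyond the scatter) and provides the first step that can be read at a single place. The read-out therefore responds to this position even though the change is small in the counted terms: the substituent goes from 10 heavy atoms to 9, while the carbon-only aromatic ring, the double bond outside it, the hydrogen-bond donor and the hydrogen-bond acceptor all remain. No supporting data bear on what lies behind this step.

This single pair leaves open whether the lower number belongs to 2-carboxyphenyl itself or would persist with other groups at this oxygen, such as a tetrazole or an amide in place of the carboxylic acid, or a longer chain carrying the acid. It also leaves open whether the same change would give a step of similar size on a different core, including that of compound 2, or with a different chain linking the two aromatic parts of the shared core.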